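Halogen swap at the meta position: compound 4 outlook

The source may report more compounds than this note shows. Statements on the series, on what has been measured and on what is new or still open speak of the compounds shown alone.

Measured so far:
- compound 1, `O=C1/C(=C/c2ccccc2)CCC/C1=C\c1ccccc1Cl`: 43%
- compound 2, `O=C1/C(=C/c2ccccc2)CCC/C1=C\c1cccc(Br)c1`: 27.2%
- compound 3, `O=C(C1=C(O)/C(=C/c2cccc(O)c2)CCC1)c1ccccc1`: 43.2%

In an assay on isolated protein for inhibition of Alpha glucosidase (Homo sapiens), with stated times of 5 min and 15 min, tested at 50 uM (a lower number here means less inhibition, a higher number more inhibition at the concentration tested (going by the name of the read-out)), compound 2 stands lowest of the three numbers. Compound 1 gives 43% and compound 3 gives 43.2% in this assay; the gap from compound 2 to either is beyond the scatter, so compound 2 gives the lowest inhibition number of the set at the concentration tested. Compound 1 and compound 3 lie within the scatter of each other.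

The unmeasured compound 4, `O=C1/C(=C/c2ccccc2)CCC/C1=C\c1cccc(F)c1`, differs from compound 2 in one place: fluoro in place of bromo on an aromatic carbon.

Among the measured compounds shown here, the one step that bears on it is a number 15.8 percentage points lower from compound 1 to compound 2 (beyond the scatter), which changes both the halogen and its position, so it does not isolate the effect of the halogen alone. For the measured compounds named here, no step in the set keeps the position and varies only the halogen. The expectation for compound 4 in this assay is therefore a step of a number 2.8 percentage points higher from compound 2 to compound 4 (within the scatter), small and not clearly beyond the scatter. Compound 4 is estimated at 30%, with a range from 15% to 46%.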

Compound 4, a percentage reported as inhibition, at one concentration (the size of the read-out at that concentration, not a potency): 39.8%
The estimate for compound 4 lay 9.8 percentage points below the measured number, and the stated range covers the measured number.
By their numbers in this assay, from the lowest: compound 2; then compounds 4, 1 and 3 (each within the scatter of the next).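

Holding the substituent on this aromatic carbon of the ring and changing only the halogen, this assay shows a number 12.6 percentage points higher from compound 2 to compound 4 (beyond the scatter) for fluoro in place of bromo. The halogen alone therefore moves the number at this place, which the earlier step, with halogen and position changing together, could not show. With a number 3.2 percentage points lower from compound 1 to compound 4 (within the scatter) as a further comparison, the low number of compound 2 is specific to the bromo compound among the halogen compounds shown, not common to all of them.

Still open, as far as these compounds go, is whether chloro on this same aromatic carbon, or a non-halogen group such as an amine or a carboxylic acid, would follow fluoro or bromo. The series carries no measurement that accounts for the gap between fluoro and bromo.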